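Swapping the group on the triazole nitrogen

The source may report more compounds than this note shows. Statements on the series, on what has been measured and on what is new or still open speak of the compounds shown alone.

Compound 1 `COc1ccc(C[C@H]2COC(=O)[C@@H]2Cc2ccc(OCc3cn(-c4ccc(F)cc4)nn3)c(OC)c2)cc1OC` — >= 600000 nM, a limit of the assay.
Compound 2 `COc1ccc(C[C@H]2COC(=O)[C@@H]2Cc2ccc(OCC(=O)N3CCCCC3)c(OC)c2)cc1OC` — 293000 nM.
Compound 3 `CCN1CCN(C(=O)CCC(=O)Oc2ccc(C[C@H]3C(=O)OC[C@@H]3Cc3ccc(OC)c(OC)c3)cc2OC)CC1` — 190000 nM.

Of the compounds shown here, three with the shared core have been measured in an ADME assay on HeLa cells (Homo sapiens) for cytotoxicity, read by MTT assay; a higher number here means a weaker inhibitor, a lower number a stronger inhibitor. Compound 1 gives only >= 600000 nM, which is a limit of the assay and not a number. Compound 1 therefore sits at the limit of >= 600000 nM in this assay, at which 1 of the 3 values shown sits. Compound 2 gives 293000 nM in this assay. Compound 3 gives 190000 nM in this assay. For the measured compounds named here, the only step between two compounds that differ in a single place is an at least 2.0-fold lower number from compound 1 to compound 2 (0.31 log units; beyond the scatter).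

Compound 4 `COc1ccc(C[C@H]2COC(=O)[C@@H]2Cc2ccc(OCc3cn(Cc4ccccc4)nn3)c(OC)c2)cc1OC` differs from compound 1 by benzyl in place of 4-fluorophenyl on an aromatic nitrogen. Going by the values given here, no measured step bears directly on this change: the step from compound 1 to compound 2 replaces the whole triazole rather than altering what sits on its ring nitrogen. All three measured values lie at very weak inhibition, and compound 1 itself reaches only the limit. On that basis the step from compound 1 to compound 4 is expected to be an at least 1.3-fold lower number from compound 1 to compound 4 (0.12 log units; that floor lies within the scatter), not beyond the scatter. Compound 4 is estimated at 450000 nM, with a range from 150000 nM to 2000000 nM, and a limit rather than a number is considered quite possible.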

Compound 4, half-maximal inhibitory concentration: 346000 nM
Compound 4: the middle estimate sits 1.3-fold (0.11 log units) above what was measured, and the stated range covers the measured number.
By their numbers in this assay, from the lowest: compounds 3, 2 and 4 (each within the scatter of the next). At a limit, above all of these: compound 1.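

In this assay, benzyl in place of 4-fluorophenyl on the aromatic nitrogen gives an at least 1.7-fold lower number from compound 1 to compound 4 (0.23 log units; that floor lies within the scatter), so this change is not shown to move the number beyond the scatter, though the true step may be larger. From the compounds shown here alone, that step stays open at one end, since the value for compound 1 is a limit and not a number: the limit of >= 600000 nM in this assay, at which 1 of the 4 values shown sits. The new compound also bears on the earlier replacement of the whole triazole: 1-benzyl-1H-1,2,3-triazol-4-yl in place of (piperidin-1-yl)carbonyl gives a 1.2-fold higher number from compound 2 to compound 4 (0.07 log units; within the scatter), so with benzyl on the nitrogen, the triazole and the piperidine amide cannot be told apart in this assay.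

The compounds shown leave open what a plain phenyl group or a 2-phenylethyl chain on that aromatic nitrogen would give, which would separate the fluorine from the chain carbon of benzyl. Going by these compounds, it also remains open whether an amine or a carboxylic acid on the group at that nitrogen would shift the number beyond the scatter.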